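Chloro for Bromo: Expected Growth Inhibition of Compound 4

The source may report more compounds than this note shows. Statements on the series, on what has been measured and on what is new or still open speak of the compounds shown alone.

Of the compounds shown here, three sharing a core have been tested in a functional assay on SW1573 cells (Homo sapiens) for inhibition, read by sulforhodamine B assay, with a stated time of 48 h; on this read-out higher numbers stand for weaker inhibition of growth and lower numbers for stronger inhibition of growth. Compound 1 `COC(=O)[C@@]1(C)CCC=C2[C@@H]1CC[C@@H](C)[C@]2(C)Cc1c[nH]c2ccc(Br)cc12` gives 12000 nM in this assay. Compound 2 `COC(=O)[C@@]1(C)CCC=C2[C@@H]1CC[C@@H](C)[C@]2(C)Cc1c[nH]c2ccc(Cl)cc12` differs from compound 1 only by chloro in place of bromo on an aromatic carbon, and in this assay compound 2 gives 11000 nM. The step of a 1.1-fold lower number from compound 1 to compound 2 (0.04 log units; within the scatter) shows that exchanging these two halogens left the read-out essentially unchanged. Compound 3 `COC(=O)[C@@]1(C)CCC=C2[C@@H]1CC[C@@H](C)[C@]2(C)Cc1c(C)[nH]c2c(Br)cccc12` carries a methyl on the ring bearing the amide-like hydrogen and places its bromo differently; the difference between the core of compound 3 and the core of compound 1 is not broken down here. In this assay compound 3 gives 25000 nM, the highest number among the three.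

Compound 4 `COC(=O)[C@@]1(C)CCC=C2[C@@H]1CC[C@@H](C)[C@]2(C)Cc1c(C)[nH]c2c(Cl)cccc12` has not yet been measured. It differs from compound 3 by chloro in place of bromo on an aromatic carbon. This is the same kind of change as that from compound 1 to compound 2, but not the same: in compound 1 the site is meta to a fused ring and para to a fused ring, whereas in compound 3 it is ortho to a fused ring and meta to a fused ring.

Because the step of a 1.1-fold lower number from compound 1 to compound 2 (0.04 log units; within the scatter) lay within the scatter, the step from compound 3 to compound 4 is expected to be a 1.1-fold lower number from compound 3 to compound 4 (0.04 log units; within the scatter). Compound 4 is therefore estimated to give 23000 nM in this assay. The expected range for compound 4 runs from 12000 nM to 45000 nM.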

Compound 4, concentration for 50% growth inhibition: 19000 nM
The estimate for compound 4 lay 1.2-fold (0.08 log units) above the measured number, and the stated range covers the measured number.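

In this assay, putting chloro in place of bromo on the second core gives a 1.3-fold lower number from compound 3 to compound 4 (0.12 log units; within the scatter), so the exchange again leaves the read-out essentially unchanged. Set side by side, the two results agree, which means that in this series the step seen on one core carried over to the other: the same change on two cores in this assay, a 1.1-fold lower number (0.04 log units; within the scatter) from compound 1 to compound 2 and a 1.3-fold lower number (0.12 log units; within the scatter) from compound 3 to compound 4, 1.2-fold (0.08 log units) apart, within the scatter of two such steps. This shows only that the two halogens were interchangeable on these two cores, at these two sites on the aromatic ring, in this one growth read-out; it does not show that the same would hold on a further core, and it does not explain why the exchange made so little difference.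

The compounds shown leave open whether a group of a different kind on this aromatic carbon, such as an amine, a methoxy or a carboxylic acid, would move the number beyond the scatter, since chloro and bromo are the only groups compared there. They also leave open how much the added methyl and the different halogen site each contribute to the gap between the two cores, as those cores differ in more than one place and no compound shown separates the two changes.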